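The compounds below may be only part of what the source reports. "The series", "measured", "known", "first", "only" and "open" are said of these compounds alone.

Two compounds with a shared core were measured in an ADME assay on the whole organism for pharmacokinetics, with Rattus norvegicus as the target, at a dose of 1 mg/kg by the oral route; a higher number here means more compound in the circulation at the dose given, a lower number less compound in the circulation: compound 1 `CC(C)CC1(O)CCN(C(=O)Nc2cc(Oc3ccc(F)cc3)cc(Oc3ccc(C4(C(=O)O)CC4)cc3)c2)CC1` gives 110 nM, and compound 2 `CC(C)CC1(O)CCN(C(=O)Nc2cc(Oc3ccc(F)cc3)cc(Oc3ccc(C(=O)O)cc3)c2)CC1` gives 34.5 nM. Within the data shown here, the only change between them is a 3.2-fold lower number from compound 1 to compound 2 (0.50 log units; beyond the scatter), so compound 2 stands lowest of the two numbers, with compound 1 as its nearest neighbour. Compound 3 `CC(C)CC1(O)CCN(C(=O)Nc2cc(Oc3ccc(C(=O)O)cc3)cc(Oc3ccc(F)cc3F)c2)CC1` differs from compound 2 by fluoro in place of hydrogen on an aromatic carbon; seen one bond further out, this reads 4-fluorophenoxy to 2,4-difluorophenoxy. Among the measured compounds shown here, no measured step touches that part of the molecule: the one known step concerns the carboxy group and says nothing about a second fluoro on the other ring. For the measured compounds named here, with no comparable step to lean on, the expectation for compound 3 in this assay is a change that stays within the usual scatter. Compound 3 is therefore estimated at 38 nM, with a likely range from 13 nM to 110 nM. The expected step is a 1.1-fold higher number from compound 2 to compound 3 (0.04 log units; within the scatter).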

Compound 3, maximal plasma concentration: 18.5 nM
The estimate for compound 3 lay 2.1-fold (0.31 log units) above the measured number, within the range that was stated.
By their numbers in this assay, from the lowest: compounds 3 and 2 (each within the scatter of the next); then compound 1.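

In this assay, the second fluoro, on an aromatic carbon ortho to a large group, turning 4-fluorophenoxy into 2,4-difluorophenoxy, gives a 1.9-fold lower number from compound 2 to compound 3 (0.27 log units; within the scatter) and so leaves compound 2 and compound 3 within the scatter of each other. Among these compounds, this is the first reading from the fluorinated side of the molecule, and at this position the swap of hydrogen for fluoro does not separate the two compounds, whereas the earlier change at the carboxy group gave a 3.2-fold lower number from compound 1 to compound 2 (0.50 log units; beyond the scatter) and lay beyond the scatter. Nothing measured here bears on why the number came out as it did.

Going by these compounds, a larger group at this position, such as chloro, methoxy or trifluoromethyl, remains open. So does whether the 2,4-difluorophenoxy group would give a similar reading alongside the 1-carboxycyclopropyl group of compound 1.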